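This account rests on a few compounds, and the source may have more. Where it says the series, first, only, none or still open, it means among the compounds named here.

Three compounds share a carbohydrate-derived core and differ in the aryl group and in the heteroaryl group carried on the sulfur. Compound 1 `Nc1nnc(SC[C@H]2O[C@@H](OCc3noc(-c4ccc(Cl)cc4)n3)[C@@H]3OC4(CCCC4)O[C@@H]32)s1` gives 17000 nM in a functional assay on SW1573 cells (Homo sapiens) for antiproliferative activity, read by sulforhodamine B assay, with a stated time of 48 h; on this read-out higher numbers stand for weaker inhibition of growth and lower numbers for stronger inhibition of growth. Compound 2 `CC(=O)OC[C@H]1O[C@@H](OCc2noc(-c3ccc([N+](=O)[O-])cc3)n2)[C@@H]2OC3(CCCC3)O[C@@H]21` gives 29000 nM in this assay. Compound 3 `COc1cc(-c2nc(CO[C@@H]3O[C@H](CSc4ncn[nH]4)[C@H]4OC5(CCCC5)O[C@@H]34)no2)cc(OC)c1OC` gives 36000 nM in this assay, the highest number of the three; compound 2 sits within the scatter of it, while compound 1 lies beyond the scatter. Compound 4 `COc1cc(-c2nc(CO[C@@H]3O[C@H](CSc4nnc(N)s4)[C@H]4OC5(CCCC5)O[C@@H]34)no2)cc(OC)c1OC` carries a change (5-amino-1,3,4-thiadiazol-2-yl in place of 1H-1,2,4-triazol-5-yl on a sulfur). Among the measured compounds shown here, no measured pair isolates this change, so the expected step of a 1.3-fold lower number from compound 3 to compound 4 (0.11 log units; within the scatter) from compound 3 to compound 4 is small, towards stronger inhibition, and likely within the scatter. Compound 4 is expected to give about 28000 nM, between 12000 nM and 60000 nM.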

Compound 4, concentration for 50% growth inhibition: 38000 nM
Estimate against measurement, compound 4: 1.4-fold (0.13 log units) below, within the range that was stated.
By their numbers in this assay, from the lowest: compounds 1, 2, 3 and 4 (each within the scatter of the next, the first and the last beyond it).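

In this assay, the pair differing only on the sulfur gives a 1.1-fold higher number from compound 3 to compound 4 (0.02 log units; within the scatter), so 5-amino-1,3,4-thiadiazol-2-yl and 1H-1,2,4-triazol-5-yl cannot be told apart here. With 5-amino-1,3,4-thiadiazol-2-yl held constant, 3,4,5-trimethoxyphenyl in place of 4-chlorophenyl gives a 2.2-fold higher number from compound 1 to compound 4 (0.35 log units; beyond the scatter), a modest step towards weaker inhibition of growth. No evidence is available to explain either step. The compounds shown leave open whether a carboxylic acid or an amine chain on the sulfur, in place of these heteroaryl groups, would shift growth inhibition.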